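Shortening the hydroxamate chain of a pyrazole sulfonamide

The compounds below may be only part of what the source reports. "The series", "measured", "known", "first", "only" and "open" are said of these compounds alone.

Measured so far:
compound 1, `Cc1ccc(-c2cc(C(=O)NCCCCCCC(=O)NO)nn2-c2ccc(S(N)(=O)=O)cc2)cc1`, gives 520 nM in an assay on isolated protein for inhibition of histone deacetylase 8 (Homo sapiens), with a stated time of 2.5 h; a higher number here means a weaker inhibitor, a lower number a stronger inhibitor.
compound 2, `COC(=O)Cc1c(C)n(Cc2ccc(-c3cn(CCCCCCCC(=O)NO)nn3)cc2)c2ccc(OC)cc12`, gives 394 nM in this assay.

Of the compounds shown here, two have been measured in this assay. Compound 1 and compound 2 share only the hydroxamic acid end of a long saturated chain; the rest of each molecule is different, and nothing connects them by a single change. Their two numbers lie within the usual scatter of each other, so neither can be called the stronger or the weaker of the pair.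

Compound 3, `Cc1ccc(-c2cc(C(=O)NCCCCCC(=O)NO)nn2-c2ccc(S(N)(=O)=O)cc2)cc1`, has not yet been measured. It differs from compound 1 in one place: hydroxycarbamoyl in place of (hydroxycarbamoyl)methyl on a saturated chain carbon, five bonds along the chain from an amide-type nitrogen. In plain words, the chain between the amide and the hydroxamic acid is one carbon shorter, with everything else unchanged.

Within the data shown here, no measured pair shows what such a shortening does here, so the expectation rests on compound 1 alone. Compound 3 is expected to give 750 nM, with a range from 250 nM to 2500 nM. That estimate means a step of a 1.4-fold higher number from compound 1 to compound 3 (0.16 log units; within the scatter), a modest weakening that may not rise beyond the scatter.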

Compound 3, half-maximal inhibitory concentration: 544 nM
The estimate for compound 3 lay 1.4-fold (0.14 log units) above the measured number, and the stated range covers the measured number.
By their numbers in this assay, from the lowest: compounds 2, 1 and 3 (each within the scatter of the next).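

In this assay, putting hydroxycarbamoyl in place of (hydroxycarbamoyl)methyl on a saturated chain carbon, five bonds along the chain from an amide-type nitrogen, gives a 1.0-fold higher number from compound 1 to compound 3 (0.02 log units; within the scatter). Among these compounds, this is the first pair that differs in one place, and it shows that, on this core, the chain can be shortened at this position without a change beyond the scatter, so the two chain lengths cannot be told apart by this read-out. Nothing measured accounts for this result, and the finding rests on this single pair.

The compounds shown leave open whether a longer chain than that of compound 1, or a chain shortened further towards 2-(hydroxycarbamoyl)ethyl or (hydroxycarbamoyl)methyl, would stay within the scatter of these values. They also leave open what a carboxylic acid in place of the hydroxamic acid would do at the chain end, and whether the same shortening would read alike on the chain of compound 2.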